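A hydroxy group added to compound 1

The source may hold more compounds than are shown below. What is called first, only, known or untested is meant among the compounds shown, and "the series" means these compounds.

Compound 1 `COc1ccc(-c2ccc(-c3ccc(-c4nc5ccccc5[nH]4)cc3)cc2)cc1`: 33300 nM
Compound 2 `CN(C)c1ccc(-c2ccc(-c3ccc(-c4nc5ccccc5[nH]4)cc3)cc2)cc1`: 41200 nM
Compound 3 `Clc1cccc(-c2ccc(-c3ccc(-c4nc5ccccc5[nH]4)cc3)cc2)c1`: 36300 nM

In a functional assay on MCF7 cells (Homo sapiens) for inhibition, read by sulforhodamine B assay (a higher number here means a weaker inhibitor of growth, a lower number a stronger inhibitor of growth), compound 1 gives 33300 nM, and it cannot be separated from its two neighbours: a 1.2-fold higher number from compound 1 to compound 2 (0.09 log units; within the scatter) and a 1.1-fold higher number from compound 1 to compound 3 (0.04 log units; within the scatter). The a 1.1-fold lower number from compound 2 to compound 3 (0.05 log units; within the scatter) is equally small. The three compounds therefore stand level, with no order among them.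

Compound 4 `COc1ccc(-c2ccc(-c3ccc(-c4nc5c(O)cccc5[nH]4)cc3)cc2)cc1` is compound 1 with one change, hydroxy in place of hydrogen on an aromatic carbon, turning 1H-benzimidazol-2-yl into 4-hydroxy-1H-benzimidazol-2-yl. The measured steps bear on it only weakly. They exchange the methoxy or the whole 4-methoxyphenyl group, and none alters the 1H-benzimidazol-2-yl group. Within the data shown here, they show tolerance of change elsewhere in the molecule, and the data hold no measured step at the place of the new hydroxy. No shift beyond the scatter can be argued from them, so the expected 1.1-fold lower number from compound 1 to compound 4 (0.05 log units; within the scatter) is small, though uncertain in direction. Compound 4 is estimated at 30000 nM, with an expected range of 10000 nM to 65000 nM.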

Compound 4, concentration for 50% growth inhibition: 3110 nM
For compound 4 the middle estimate is 9.6-fold (0.98 log units) above the measured one; measured number outside the range, below it.
By their numbers in this assay, from the lowest: compound 4; then compounds 1, 3 and 2 (each within the scatter of the next).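

In this assay the change from 1H-benzimidazol-2-yl to 4-hydroxy-1H-benzimidazol-2-yl gives an 11-fold lower number from compound 1 to compound 4 (1.03 log units; beyond the scatter), so this position responds strongly, whereas exchanging the methoxy or the whole 4-methoxyphenyl group among compounds 1, 2 and 3 moved nothing beyond the scatter. The group that enters holds a single heavy atom, one oxygen, yet its step is the only one shown here that lies beyond the scatter. Nothing at hand gives a reason for this step.

The compounds shown do not tell whether a methoxy, an amine or a fluorine at the same place would give a step of similar size, or whether the hydroxy is needed as such. They also leave open whether the same hydroxy would act alike with the dimethylamino group of compound 2 or the 3-chlorophenyl group of compound 3.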